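A few compounds are considered here, and "the series" means these few. Any claim that something is new, unique, unknown or untested is made for them only; others in the source may bear on it.

Measured so far in a functional assay on A549 cells (Homo sapiens) for cytotoxicity, read by MTT assay, with a stated time of 48 h; a lower number here means a stronger inhibitor, a higher number a weaker inhibitor:
- compound 1 `O=C(/C=C/c1ccccc1F)Nc1ccc(CC2=CC(=O)OC2)cc1`: 40000 nM
- compound 2 `C=C1OC(=O)C=C1Cc1ccc(NC(=O)/C=C/c2ccc(F)cc2)cc1`: 3460 nM
- compound 3 `C=C1OC(=O)C=C1Cc1ccc(NC(=O)c2ccccc2)cc1`: 49800 nM

Compound 2 stands lowest of the three numbers in this assay. Its nearest neighbour is compound 1, whose number is higher by a margin beyond the scatter; compound 3 lies furthest, also beyond the scatter. Among the measured set, then, compound 2 is the strongest inhibitor.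

Compound 4 `C=C1OC(=O)C=C1Cc1ccc(NC(=O)/C=C/c2ccccc2F)cc1` has not yet been measured in this assay. It shares its atoms with compound 2 and differs only in how they are joined: 2-fluorophenyl in place of 4-fluorophenyl on a double-bonded chain carbon bound to a double-bonded chain carbon. Going by the values given here, no pair of measured compounds differs in this one place alone, so the size of the step is open. Compound 1 also carries a 2-fluorophenyl group, though on the core of compound 1 rather than that of compound 2; in this assay compound 1 gives 40000 nM, a value that does not isolate the change but gives no ground to expect compound 4 to improve on compound 2.

The expectation is a moderate loss, a step of a 2.9-fold higher number from compound 2 to compound 4 (0.46 log units; beyond the scatter) toward a higher number, likely beyond the scatter but short of the gap to compound 1. Compound 4 is accordingly estimated at 10000 nM, with a range of 3000 nM to 40000 nM.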

Compound 4, half-maximal inhibitory concentration: 7410 nM
Estimate against measurement, compound 4: 1.3-fold (0.13 log units) above; the measured number falls inside the stated range.
By their numbers in this assay, from the lowest: compound 2; then compound 4; then compounds 1 and 3 (each within the scatter of the next).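

In this assay, going by these compounds alone, 2-fluorophenyl in place of 4-fluorophenyl on a double-bonded chain carbon bound to a double-bonded chain carbon gives a 2.1-fold higher number from compound 2 to compound 4 (0.33 log units; beyond the scatter), the first direct reading at this position, and it shows a modest loss with the same atoms rearranged. With 2-fluorophenyl held constant, the shared-side change of the group of 7 heavy atoms for the group of 6 heavy atoms gives a 5.4-fold lower number from compound 1 to compound 4 (0.73 log units; beyond the scatter), so the core of compound 4 retains a modest gain over the core of compound 1 with this substituent. No available evidence bears on the origin of either step.

Going by these compounds, whether the core step has a similar size with 4-fluorophenyl remains open. Also open, on these data alone, is how a chlorine or a methoxy group would compare with the fluorine on this phenyl ring.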